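The source may report more compounds than this note shows. Statements on the series, on what has been measured and on what is new or still open speak of the compounds shown alone.

Measured compounds:
- compound 1 `O=[N+]([O-])c1ccc(C2=NOC(c3ccccc3)O2)s1`: < 180000 nM
- compound 2 `COc1ccc(C2ON=C(c3ccc([N+](=O)[O-])s3)O2)cc1`: < 180000 nM
- compound 3 `Cc1ccc(C2=NOC(c3ccccc3)O2)cc1`: "not determined" (no result reported)

Working notes. In an ADME assay on Vero cells (Chlorocebus sabaeus) for cytotoxicity, read by sulforhodamine B assay, with a stated time of 72 h (a higher number here means a weaker inhibitor, a lower number a stronger inhibitor), compound 1 gives < 180000 nM, which is a limit of the assay and not a number. In this assay compound 2 likewise gives < 180000 nM, again a limit. The change from compound 1 to compound 2 is methoxy in place of hydrogen on an aromatic carbon, and the step that the two limits leave unreadable from compound 1 to compound 2 cannot be read because the limit of < 180000 nM in this assay, at which 2 of the 3 values shown sit, is where both values sit. Compound 3 has no value in this assay. The difference between the core of compound 1 and the core of compound 3 is not broken down here.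

Compound 4 `COc1ccc(C2ON=C(c3ccc(C)cc3)O2)cc1` is the one not yet measured. It differs from compound 3 by methoxy in place of hydrogen on an aromatic carbon; this is the same change as from compound 1 to compound 2, occurring twice among the compounds shown. Since that earlier step is unreadable and compound 3 itself has no value, there is no measured anchor for the size of the step from compound 3 to compound 4 in this assay. An estimate for compound 4 in this assay of 100000 nM, between 20000 nM and 500000 nM, is expected to rest only on the two limits seen so far.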

Compound 4, half-maximal inhibitory concentration: > 180000 nM
Compound 4 ended at the assay's limit; the forecaster's own chance of this, stated with the estimate: 60%; middle value at least 1.8-fold (0.25 log units) from the limit.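

In this assay compound 4 gives > 180000 nM, which is a limit of the assay and not a number. Going by these compounds alone, compound 3 has no value here, so no step from compound 3 to compound 4 can be read. The compounds shown leave open how large the change from hydrogen to methoxy is in this assay, on either core.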